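Swapping Methylsulfonyl for Methylsulfanyl on a Shared Core

This account rests on a few compounds, and the source may have more. Where it says the series, first, only, none or still open, it means among the compounds named here.

Of the compounds shown here, three have been tested in a functional assay on the whole organism for antagonist activity, with Mus musculus as the target; a lower number here means that less compound is needed, a higher number that more compound is needed for the effect. Compound 1 `Cn1c(-c2cccc(F)c2)nnc1S(C)(=O)=O` carries a methylsulfonyl group; in this assay compound 1 gives > 200 mg/kg, which is a limit of the assay rather than a number. Compound 3 `Cn1c(-c2cccc3ccccc23)nnc1S(C)(=O)=O` also carries methylsulfonyl; in this assay compound 3 gives > 200 mg/kg, again a limit. Compound 2 `CSc1nnc(-c2cccc3ccccc23)n1C` carries methylsulfanyl instead; in this assay compound 2 gives > 200 mg/kg, also a limit. The change from compound 3 to compound 2 is methylsulfanyl in place of methylsulfonyl on an aromatic carbon and its step is a step that the two limits leave unreadable from compound 3 to compound 2. The difference between the core of compound 1 and the core of compound 3 is not broken down here. Compound 4 `CSc1nnc(-c2cccc(F)c2)n1C` is not yet measured; the change from compound 1 to compound 4 is methylsulfanyl in place of methylsulfonyl on an aromatic carbon. It is the same kind of change as from compound 3 to compound 2, differing in its surroundings: there the place is two ring bonds from the ring atom that bears a large group, here two ring bonds from the ring atom that bears a group of 7 heavy atoms. The step from compound 1 to compound 4 is expected to be a step that the limit leaves unreadable from compound 1 to compound 4 because every value shown sits at the limit of > 200 mg/kg in this assay, at which 3 of the 3 values shown sit, leaving no readable size to carry over. Compound 4 is therefore expected to give 300 mg/kg, between 100 mg/kg and 1000 mg/kg.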

Compound 4, dose for half-maximal effect: > 200 mg/kg
Compound 4: only a limit was reported (the forecaster's own chance of this, stated with the estimate: 85%); the middle value lies beyond the limit too.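

Compound 4, like compound 1, reaches only a limit of the assay, so no size can be read for the change from methylsulfonyl to methylsulfanyl between them: the limit of > 200 mg/kg in this assay, at which 4 of the 4 values shown sit. The compounds shown leave open whether this change alters the dose needed in this assay at all, and how large any such effect would be.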